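The compounds below may be only part of what the source reports. "The series", "measured", "known", "first", "only" and "open" are said of these compounds alone.

Compound 1 `CCC(c1ccccc1)c1cc(O)nc(SC(C)C)n1`: > 200000 nM (a limit)
Compound 2 `CCC(C)Sc1nc(O)cc(C(CC)c2ccccc2)n1`: > 200000 nM (a limit)
Compound 3 `CC(c1ccccc1)c1cc(O)nc(SC2CCCC2)n1`: 159000 nM

All three were tested in a functional assay on MT4 cells (Homo sapiens) for cytotoxicity; a higher number here means that more compound is tolerated, a lower number that less compound is tolerated. For the measured compounds named here, compound 3 holds the only true number here, 159000 nM. The other two values are limits: the limit of > 200000 nM in this assay, at which 2 of the 3 values shown sit.

Compound 4 `CCC(c1ccccc1)c1cc(O)nc(SC2CCCC2)n1` differs from compound 3 by one change: methyl in place of hydrogen on a saturated chain carbon, two bonds along the chain from two aromatic carbons. Cut one bond further out, this reads methyl to ethyl. Going by the values given here, the only measured step of this kind, a step that the two limits leave unreadable from compound 1 to compound 2, lies two bonds along the chain from a sulfur, at a different place, and gives no size to carry over. No change beyond the scatter is therefore expected in this assay, and the expected step is a 1.1-fold lower number from compound 3 to compound 4 (0.03 log units; within the scatter). Compound 4 is estimated at 150000 nM, with an expected range of 80000 nM to 280000 nM.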

Compound 4, half-maximal cytotoxic concentration: 50000 nM
The estimate for compound 4 lay 3.0-fold (0.48 log units) above the measured number; the measured number lies below the stated range.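

In this assay, methyl in place of hydrogen on this saturated chain carbon gives a readable step, a 3.2-fold lower number from compound 3 to compound 4 (0.50 log units; beyond the scatter), whereas the earlier methyl step near the sulfur could not be read. With ethyl on this carbon, the groups on the sulfur also separate: cyclopentyl in place of sec-butyl gives an at least 4.0-fold lower number from compound 2 to compound 4 (0.60 log units; beyond the scatter), and cyclopentyl in place of isopropyl gives an at least 4.0-fold lower number from compound 1 to compound 4 (0.60 log units; beyond the scatter). Both of these steps start from a limit and not from a number: the limit of > 200000 nM in this assay, at which 2 of the 4 values shown sit.

From the compounds shown here alone, whether methyl has the same effect with isopropyl or sec-butyl on the sulfur stays open. So does the outcome with a propyl chain or an amine at this carbon.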